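This account rests on a few compounds, and the source may have more. Where it says the series, first, only, none or still open, it means among the compounds named here.

Compound 2 `COc1ccc(F)cc1CNCCCNc1ccnc2cc(CC(C)C)ccc12` gives 9.47 in a physicochemical assay for acid dissociation, the highest of the two numbers there, and its nearest neighbour is compound 1 `COc1cccc(Oc2ccc3c(NCCCNCc4cc(F)ccc4OC)ccnc3c2)c1`, which gives 9.28, a gap within the scatter. Compound 3 `COc1ccc(F)cc1CNCCCNc1ccnc2cc(-c3ccccc3)ccc12` differs from compound 2 by phenyl in place of isobutyl on an aromatic carbon. Within the data shown here, only one measured step bears on this change, because a number 0.19 log units higher from compound 1 to compound 2 (within the scatter) was itself an exchange of the group on an aromatic carbon of the shared core, and it stayed within the scatter. Compound 3 is therefore expected to show no step beyond the scatter, a number 0.07 log units lower from compound 2 to compound 3 (within the scatter). Compound 3 is estimated at 9.4, within a range from 9 to 9.8.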

Compound 3, acid dissociation constant: 9.47
Beside the measured number, compound 3's estimate is 0.07 log units below it; measured number inside the range.
By their numbers in this assay, from the lowest: compounds 1, 2 and 3 (each within the scatter of the next).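

In this assay, phenyl in place of isobutyl on this aromatic carbon gives no change at the digits printed from compound 2 to compound 3 (within the scatter), while phenyl in place of 3-methoxyphenoxy gives a number 0.19 log units higher from compound 1 to compound 3 (within the scatter). With a third group now in place, all three compounds lie within the scatter of one another, so exchanging a branched chain for an aromatic ring at this position brings no step beyond it. Nothing available explains this result. From the compounds shown here alone, whether an amine or a carboxylic acid at this position would leave the number within the scatter remains open. So does the outcome of any change elsewhere on the shared core.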